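A new aryl group on the sulfonyl sulfur

A few compounds are considered here, and "the series" means these few. Any claim that something is new, unique, unknown or untested is made for them only; others in the source may bear on it.

Compound 1 `N#Cc1ccc(O[C@H]2CN(S(=O)(=O)c3ccc(C(F)(F)F)cc3)C[C@@]2(O)CO)cc1F`: 100%
Compound 2 `N#Cc1ccc(O[C@H]2CN(S(=O)(=O)c3ccc(Cl)cc3Cl)C[C@@]2(O)CN)cc1F`: 24%

Both values come from an ADME assay on the whole organism (Rattus norvegicus, strain Sprague-Dawley) for pharmacokinetics, read by LC-MS; on this read-out higher numbers stand for higher oral bioavailability and lower numbers for lower oral bioavailability. Compound 1 stands higher at 100%, and compound 2 gives 24%. That gap lies beyond the scatter. These two compounds differ in more than one place, so their gap isolates no single change. Compound 3 `N#Cc1ccc(O[C@H]2CN(S(=O)(=O)c3ccccc3C#N)C[C@@]2(O)CO)cc1F` carries 2-cyanophenyl in place of 4-(trifluoromethyl)phenyl on a sulfonyl sulfur. With compound 1 already at 100%, little room remains upward, so a moderate drop beyond the scatter is expected. The expected change is a number 40 percentage points lower from compound 1 to compound 3 (beyond the scatter). Compound 3 is estimated at 60%, with a range of 30% to 95%.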

Compound 3, oral bioavailability: 32%
Compound 3: middle estimate off by 28 percentage points, on the high side, within the range that was stated.
By their numbers in this assay, from the lowest: compounds 2 and 3 (each within the scatter of the next); then compound 1.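

Going by these compounds alone, with the rest of the molecule unchanged, this pair gives the first single change that can be read: in this assay, 2-cyanophenyl in place of 4-(trifluoromethyl)phenyl on a sulfonyl sulfur gives a number 68 percentage points lower from compound 1 to compound 3 (beyond the scatter). Oral bioavailability therefore depends strongly on which aryl group sits at this position. Nothing measured here explains the drop.

As far as these compounds go, this single swap removes the trifluoromethyl group and adds the nitrile together, so their separate contributions stay unknown. From the compounds shown here alone, how a plain phenyl group or a pyridine ring would behave on this sulfur also remains open.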